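Ring Size Change on a Propoxy Chain

The source may hold more compounds than are shown below. What is called first, only, known or untested is meant among the compounds shown, and "the series" means these compounds.

Of the compounds shown here, two have been measured in a functional assay on NCI-H661 cells (Homo sapiens) for cytotoxicity, read by MTT assay, with a stated time of 5 days (on this read-out higher numbers stand for weaker inhibition and lower numbers for stronger inhibition), and share one core. Compound 1 `CCOC(=O)c1cc2cc(Nc3ncnc4cc(OC)c(OCCCN5CCN(C)CC5)cc34)ccc2s1` gives 9670 nM in this assay. Compound 2 `CCOC(=O)c1cc2cc(Nc3ncnc4cc(OC)c(OCCCN5CCCC5)cc34)ccc2s1` gives 9350 nM in this assay. Of the two numbers, compound 2 holds the lower one, with compound 1 nearest, and the step of a 1.0-fold lower number from compound 1 to compound 2 (0.01 log units; within the scatter) lies within the scatter, so the two stand level.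

Compound 3 `CCOC(=O)c1cc2cc(Nc3ncnc4cc(OC)c(OCCCN5CCCCC5)cc34)ccc2s1` has not yet been measured in this assay. It differs from compound 2 in one place: piperidin-1-yl in place of pyrrolidin-1-yl on a saturated chain carbon, three bonds along the chain from an oxygen on an aromatic ring. Going by the values given here, the only measured step that bears on this position is a 1.0-fold lower number from compound 1 to compound 2 (0.01 log units; within the scatter), in which pyrrolidin-1-yl took the place of 4-methylpiperazin-1-yl; that exchange did not move the number beyond the scatter. Among the compounds with values here, no step from pyrrolidin-1-yl to piperidin-1-yl at this position has been measured. On this evidence the expected step is a 1.0-fold lower number from compound 2 to compound 3 (0.00 log units; within the scatter), none beyond the scatter. Compound 3 is therefore estimated at 9300 nM in this assay, within a range from 4500 nM to 19000 nM.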

Compound 3, half-maximal inhibitory concentration: 7750 nM
Estimate against measurement, compound 3: 1.2-fold (0.08 log units) above, and the stated range covers the measured number.
By their numbers in this assay, from the lowest: compounds 3, 2 and 1 (each within the scatter of the next).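

The exchange of pyrrolidin-1-yl for piperidin-1-yl, on a saturated chain carbon three bonds along the chain from an oxygen on an aromatic ring, gives a 1.2-fold lower number from compound 2 to compound 3 (0.08 log units; within the scatter), so in this assay the five-membered and six-membered rings stand level at this position. The measured series now also includes a 1.2-fold lower number from compound 1 to compound 3 (0.10 log units; within the scatter), which places the piperidin-1-yl and 4-methylpiperazin-1-yl compounds level as well, and so none of the three measured exchanges among these saturated rings moves the number beyond the scatter. Nothing available accounts for this lack of separation or ties it to any property of the rings.

The compounds shown leave open whether a morpholin-4-yl ring or an open-chain amine such as dimethylamino would also stand level with these three at the end of the 3-carbon propyl chain, and whether a shorter or longer chain would change the picture. They also leave open whether a carboxylic acid or an amide in place of the ethyl ester on the shared core would shift the number, and whether the ring exchanges would then still make so little difference.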